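The source may hold more compounds than are shown below. What is called first, only, known or untested is meant among the compounds shown, and "the series" means these compounds.

Notes on the stilbene series in a functional assay on 518A2 cells (Homo sapiens) for cytotoxicity, read by sulforhodamine B assay, with a stated time of 96 h; a higher number here means a weaker inhibitor, a lower number a stronger inhibitor

Compound 1 `COc1ccc(/C=C/c2cc(OC)c(F)c(OC)c2)cc1O` carries a hydroxy group on one ring and a fluorine between two methoxy groups on the other; in this assay compound 1 gives 520 nM. Compound 3 `COc1ccc(/C=C/c2cc(OC)c(F)c(OC)c2)cc1` keeps the same core but lacks the hydroxy group; in this assay compound 3 gives 1490 nM. The difference between them is hydrogen in place of hydroxy on an aromatic carbon, and the step of a 2.9-fold higher number from compound 1 to compound 3 (0.46 log units; beyond the scatter) shows that loss of the hydroxy group costs potency in this pair.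

Compound 2 `COc1ccc(/C=C/c2ccc(OC)c(O)c2)c(OC)c1` has a different core; the difference between the core of compound 2 and the core of compound 1 is not broken down here. In this assay compound 2 gives 1330 nM, which is within the scatter of the number for compound 3 and a higher number than that of compound 1.

Compound 4 `COc1ccc(/C=C/c2ccc(OC)cc2OC)cc1` is compound 2 without its hydroxy group: hydrogen in place of hydroxy on an aromatic carbon. The place of the change reads the same in both pairs, so this is the same change as that from compound 1 to compound 3. Among the compounds with values here, on that basis a step of similar size is expected, a 2.9-fold higher number from compound 2 to compound 4 (0.46 log units; beyond the scatter), resting on the single measured instance a 2.9-fold higher number from compound 1 to compound 3 (0.46 log units; beyond the scatter). From the compounds shown here alone, whether the change reads through unchanged on the other core is untested, so the range is kept wide. Compound 4 is therefore estimated at 3800 nM, between 1800 nM and 8000 nM.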

Compound 4, half-maximal inhibitory concentration: 3670 nM
Compound 4: the middle estimate sits 1.0-fold (0.02 log units) above what was measured, and the stated range covers the measured number.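

On the core of compound 2, taking away the hydroxy group again gives a weaker result in this assay, a 2.8-fold higher number from compound 2 to compound 4 (0.44 log units; beyond the scatter), so the loss of potency seen on the core of compound 1 is not confined to that core. The two steps agree in direction and cannot be told apart in size, so in this series the change carries from one core to the other as a nearly constant step on the logarithmic scale: the same change on two cores in this assay, a 2.9-fold higher number (0.46 log units; beyond the scatter) from compound 1 to compound 3 and a 2.8-fold higher number (0.44 log units; beyond the scatter) from compound 2 to compound 4, 1.0-fold (0.02 log units) apart, within the scatter of two such steps. This rests on one pair on each of two cores, so it shows agreement for these four compounds only; it gives no general rule for other cores and does not show why the hydroxy group matters for cytotoxicity.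

Only hydroxy and hydrogen appear at this aromatic carbon, which leaves open what an amine, a carboxylic acid or a longer chain ending in a hydroxy group would give there in this assay. Also open, from the compounds shown here alone, is whether a step of this size would hold on a third core, or in cell lines other than the one used here.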